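A methyl-to-fluoro swap on the arylamino group

The compounds below may be only part of what the source reports. "The series", "measured", "known", "first", "only" and "open" are said of these compounds alone.

Compound 1 `CC(C)OC1=C(C(=O)c2ccccc2)C(c2ccc(Br)cc2)N(CCCn2ccnc2)C1=O` gives 23000 nM in a functional assay on SAOS-2 cells (Homo sapiens) for antiproliferative activity, read by MTT assay, with a stated time of 72 h; a higher number here means a weaker inhibitor, a lower number a stronger inhibitor.
Compound 2 `CCCCCOC1=C(C(=O)c2ccccc2)C(c2ccc(Br)cc2)N(CCCn2ccnc2)C1=O` gives 9990 nM.
Compound 3 `Cc1ccc(NC2=C(C(=O)c3ccccc3)C(c3ccc(Br)cc3)N(CCCn3ccnc3)C2=O)cc1` gives 31900 nM.

Compound 3 carries the highest of the three numbers: a 1.4-fold higher number from compound 1 to compound 3 (0.14 log units; within the scatter), and a 3.2-fold higher number from compound 2 to compound 3 (0.50 log units; beyond the scatter). Compound 4 `O=C(C1=C(Nc2ccc(F)cc2)C(=O)N(CCCn2ccnc2)C1c1ccc(Br)cc1)c1ccccc1` differs from compound 3 by fluoro in place of methyl on an aromatic carbon. Going by the values given here, no measured step touches this ring: the two steps leading to compound 3 exchange the whole group on the ring carbon, and a 2.3-fold lower number from compound 1 to compound 2 (0.36 log units; beyond the scatter) concerns the chain on oxygen, so there is no direct precedent for this exchange. A single-atom swap of this kind is expected to leave the number close to that of compound 3, a 1.1-fold lower number from compound 3 to compound 4 (0.06 log units; within the scatter), within the scatter. Compound 4 is therefore estimated at 28000 nM, with a range of 10000 nM to 80000 nM.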

Compound 4, half-maximal inhibitory concentration: 32700 nM
Compound 4: the middle estimate sits 1.2-fold (0.07 log units) below what was measured; low and high end bracket the measured number.
By their numbers in this assay, from the lowest: compound 2; then compounds 1, 3 and 4 (each within the scatter of the next).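

In this assay, going by these compounds alone, fluoro and methyl on this aromatic carbon cannot be told apart (a 1.0-fold higher number from compound 3 to compound 4 (0.01 log units; within the scatter)), which is the first direct reading of this exchange. Compound 4 also stands with compound 1 (a 1.4-fold higher number from compound 1 to compound 4 (0.15 log units; within the scatter)) and, like compound 3, remains separated from compound 2 (a 3.3-fold higher number from compound 2 to compound 4 (0.51 log units; beyond the scatter)). Nothing available explains why the two groups read alike. As far as these compounds go, whether a carboxylic acid or an amine on this ring carbon would shift the number stays open. So does whether a chain longer than pentyl on the oxygen would extend the step seen from isopropyl.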